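The source may report more compounds than this note shows. Statements on the series, on what has been measured and on what is new or still open speak of the compounds shown alone.

Measured compounds:
Compound 1, `CCCN(CCC)/C(C)=N/C1=Nc2ccc(OC(F)(F)F)cc2CS1`: 0.1 uM
Compound 2, `CCCN(CCC)/C(C)=N/C1=Nc2ccccc2SC1`: 10 uM

In a functional assay (strain Wistar) with Rattus norvegicus as the target, read by LDH release (a lower number here means that less compound is needed, a higher number that more compound is needed for the effect), compound 1 gives 0.1 uM, the lower of the two numbers recorded; compound 2 gives in this assay 10 uM, a gap beyond the usual scatter. Compound 1 and compound 2 differ in more than one place, so the gap between them cannot be attached to a single change.

Compound 3, `CCCN(CCC)/C(C)=N/C1=Nc2ccccc2CS1`, has not yet been measured. It differs from compound 1 in one place: hydrogen in place of trifluoromethoxy on an aromatic carbon. On these data alone, since compound 2, which also carries no trifluoromethoxy group, shows a much higher number than compound 1, the loss of that group is expected to raise the number, though how much of the gap belongs to it is unknown. The estimated step from compound 1 to compound 3 is a 10-fold higher number from compound 1 to compound 3 (1.00 log units; beyond the scatter). Compound 3 is expected to give about 1 uM in this assay, within a range from 0.2 uM to 10 uM.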

Compound 3, minimum effective concentration: 0.1 uM
The estimate for compound 3 lay 10-fold (1.00 log units) above the measured number; measured number outside the range, below it.
By their numbers in this assay, from the lowest: compounds 1 and 3 (each within the scatter of the next); then compound 2.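

In this assay, hydrogen can stand in place of the trifluoromethoxy group on this aromatic carbon with no change at the digits printed from compound 1 to compound 3 (within the scatter), so the group is not needed to hold the number at this level. Compound 3 lacks the group just as compound 2 does, yet compound 2 gives 10 uM and compound 3 gives 0.1 uM, so the absence of trifluoromethoxy does not by itself go with a high number. Nothing at hand explains why this exchange leaves the number in place.

Hydrogen and trifluoromethoxy are the only groups shown at this position, so it remains open whether a chlorine atom, a methoxy group or a carboxylic acid there would also leave the number unchanged. Also open, on these data alone, is how the number responds to a change elsewhere on the shared core, such as a longer chain.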